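Compound 3: a five-membered ring in place of a chain

The compounds below may be only part of what the source reports. "The series", "measured", "known", "first", "only" and "open" are said of these compounds alone.

Compound 1 `COC(=O)N(CCO)c1c(N)nc(-c2nn(Cc3ccccc3F)c3ncccc23)nc1N` gives 61.7 mL/min/kg in an ADME assay on cells (Hepatocyte, Rattus norvegicus) for pharmacokinetics, read by LC-MS, with a stated time of 90 min, tested at 1 uM (a lower number here means slower removal, a higher number faster removal of the compound), the higher of the two numbers shown, though compound 2 `COC(=O)N(Cc1cccc(F)c1)c1c(N)nc(-c2nn(Cc3ccccc3F)c3ncccc23)nc1N`, which gives 53.3 mL/min/kg, sits within the scatter of it: a 1.2-fold lower number from compound 1 to compound 2 (0.06 log units; within the scatter). Compound 3 `Nc1nc(-c2nn(Cc3ccccc3F)c3ncccc23)nc(N)c1N1C[C@@H](C(F)(F)F)OC1=O` carries a different group on the shared core: 2-oxo-5-(trifluoromethyl)-1,3-oxazolidin-3-yl in place of (2-hydroxyethyl)(methoxycarbonyl)amino on an aromatic carbon. Within the data shown here, the only measured step, from compound 1 to compound 2, also reworked the group at this same place without a clear effect, so it offers a weak guide here. Compound 3 is therefore expected to show no step beyond the scatter, a 1.1-fold lower number from compound 1 to compound 3 (0.05 log units; within the scatter). The estimated clearance of compound 3 is 55 mL/min/kg, within 25 mL/min/kg to 110 mL/min/kg.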

Compound 3, clearance: 26.7 mL/min/kg
For compound 3 the middle estimate is 2.1-fold (0.31 log units) above the measured one; measured number inside the range.
By their numbers in this assay, from the lowest: compounds 3, 2 and 1 (each within the scatter of the next, the first and the last beyond it).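

Compound 1 to compound 2 left the number unchanged within the scatter, but this position can matter in this assay: the 2-oxo-5-(trifluoromethyl)-1,3-oxazolidin-3-yl group gives a 2.3-fold lower number from compound 1 to compound 3 (0.36 log units; beyond the scatter) and a step beyond the scatter. This single change closes a ring, adds trifluoromethyl and removes a hydrogen-bond donor, so these parts cannot be separated. Nothing available explains the step. As far as these compounds go, it remains open whether the same ring with methyl or plain hydrogen in place of trifluoromethyl would give a similar number. From the compounds shown here alone, the opposite stereocentre also remains untested here.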